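The source may report more compounds than this note shows. Statements on the series, on what has been measured and on what is new or still open speak of the compounds shown alone.

Measured so far in a functional assay on MCF7 cells (Homo sapiens) for inhibition, read by CCK-8 assay, with a stated time of 48 h (a higher number here means a weaker inhibitor, a lower number a stronger inhibitor), as follows
- compound 1 `COc1cc(-c2ccnc3cc(-c4ccc(C)c(C)c4)nn23)cc(OC)c1OC` at 26 nM
- compound 2 `COc1cc(-c2ccnc3cc(-c4ccc5c(ccn5C)c4)nn23)cc(OC)c1OC` at 3 nM
- compound 3 `COc1cc(-c2ccnc3cc(-c4cn(C)c5ccccc45)nn23)cc(OC)c1OC` at 95 nM

Compound 3 at 95 nM carries the highest number of the three and is the weakest inhibitor here. The modest gap to its nearest neighbour reads a 3.7-fold higher number from compound 1 to compound 3 (0.56 log units; beyond the scatter) and the large gap to the best compound reads a 32-fold higher number from compound 2 to compound 3 (1.50 log units; beyond the scatter) in this series.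

Next comes compound 4 `COc1cc(-c2ccnc3cc(-c4ccc5cnn(C)c5c4)nn23)cc(OC)c1OC` with this difference: 1-methyl-1H-indazol-6-yl in place of 1-methyl-1H-indol-3-yl on an aromatic carbon in all. In words, 1-methyl-1H-indazol-6-yl stands in place of 1-methyl-1H-indol-3-yl on an aromatic carbon. Among the measured compounds shown here, no measured compound carries the entering group, so the guide is indirect. Both other groups gave lower numbers than 1-methyl-1H-indol-3-yl, and the step of an 8.7-fold lower number from compound 1 to compound 2 (0.94 log units; beyond the scatter) shows how far a bicyclic group can go. A clear fall is therefore expected in this assay rather than a change within the scatter. The expected step is a 7.9-fold lower number from compound 3 to compound 4 (0.90 log units; beyond the scatter) in this estimate. For compound 4 the estimated value is 12 nM with an expected range of 3 nM to 50 nM for now.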

Compound 4, half-maximal inhibitory concentration: 279 nM
For compound 4 the middle estimate is 23-fold (1.37 log units) below the measured one; the whole stated range lies below it.
By their numbers in this assay, from the lowest: compound 2; then compound 1; then compound 3; then compound 4.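

Compound 4 is the weakest inhibitor of the four, so a fused bicyclic group at this position does not by itself give a low number: the series shows a 2.9-fold higher number from compound 3 to compound 4 (0.47 log units; beyond the scatter) and also an 11-fold higher number from compound 1 to compound 4 (1.03 log units; beyond the scatter) here, while compound 2 goes against that direction. Among the compounds shown here, the widest step so far is a 93-fold higher number from compound 2 to compound 4 (1.97 log units; beyond the scatter) and it alters both the ring hetero atoms and the point of attachment, so it cannot separate these two changes. No measurement on hand bears on the reason for this result.

Open, on these data alone, is how much of the step belongs to the attachment point and how much to the second ring nitrogen. A 1-methyl-1H-indol-6-yl or 1-methyl-1H-indazol-5-yl group would separate the two.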